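Removing an acetyl from a shared core on HT-29 cells

The source may hold more compounds than are shown below. What is called first, only, known or untested is meant among the compounds shown, and "the series" means these compounds.

In a functional assay on HT-29 cells (Homo sapiens) for inhibition (on this read-out higher numbers stand for weaker inhibition and lower numbers for stronger inhibition), the measured compounds are: compound 1 `CC(=O)Oc1cc(OC(C)=O)c2c(=O)cc(-c3ccccc3)oc2c1` with 2600 nM; compound 2 `CC(=O)Oc1cc(O)c2c(=O)cc(-c3ccccc3)oc2c1` with 3800 nM; compound 3 `CC(=O)Oc1c(I)c(O)c2c(=O)cc(-c3ccccc3)oc2c1I` with 3000 nM.

Compound 1 and compound 3 share a core whose difference is not broken down here; compound 1 gives 2600 nM and compound 3 gives 3000 nM, within the scatter of each other. The change hydrogen in place of acetyl on an oxygen on an aromatic ring produced a 1.5-fold higher number from compound 1 to compound 2 (0.16 log units; within the scatter). The same change, (hydrogen in place of acetyl on an oxygen on an aromatic ring), at the same place word for word, leads to compound 4 `O=c1cc(-c2ccccc2)oc2c(I)c(O)c(I)c(O)c12`, not yet measured in this assay. Because a 1.5-fold higher number from compound 1 to compound 2 (0.16 log units; within the scatter) lay within the scatter, the step to compound 4 is expected to be a 1.3-fold higher number from compound 3 to compound 4 (0.12 log units; within the scatter). Compound 4 is therefore estimated at 4000 nM, likely between 1500 nM and 10000 nM.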

Compound 4, half-maximal inhibitory concentration: 4400 nM
Compound 4: the middle estimate sits 1.1-fold (0.04 log units) below what was measured, within the range that was stated.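

In this assay the acetoxy to hydroxy change gives a 1.5-fold higher number from compound 3 to compound 4 (0.17 log units; within the scatter). Set beside the earlier step, the change reads the same on both cores: the same change on two cores in this assay, a 1.5-fold higher number (0.16 log units; within the scatter) from compound 1 to compound 2 and a 1.5-fold higher number (0.17 log units; within the scatter) from compound 3 to compound 4, 1.0-fold (0.00 log units) apart, within the scatter of two such steps. This shows that, across these two pairs, the step carried over from one core to the other without a detectable difference, but each step lies within the scatter, so neither shows that the change affects inhibition, and two pairs set no rule for the series.

The compounds shown leave open how a longer acyl chain such as butyryl, or a methyl ether, would read on that oxygen. They also leave open whether an amine in place of the hydroxy would give a step beyond the scatter.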